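A few compounds are considered here, and "the series" means these few. Any claim that something is new, unique, unknown or untested is made for them only; others in the source may bear on it.

In an ADME assay on microsomes from liver (Mus musculus) for metabolic stability, read by LC-MS, using NADPH, with a stated time of 10 min, tested at 10 uM (on this read-out higher numbers stand for a longer-lived compound and lower numbers for a shorter-lived compound), compound 1 (`Nc1ncnc2c1c(Oc1cc(C(F)(F)F)ccn1)nn2[C@H]1CC[C@H](CO)CC1`) gives 0.383 h as its result. Compound 2 (`Nc1ncnc2c1c(Oc1cccc(Cl)c1)nn2[C@H]1C[C@H](F)C1`) gives 0.065 h on the same scale, a clearly lower number, which leaves compound 1 the higher of these two. Compound 3 (`N#Cc1ccnc(Oc2nn(C3CC3)c3ncnc(N)c23)c1`) gives > 2.41 h as a limit, not a number. Compound 4 (`Nc1ncnc2c1c(Oc1cc(C(F)(F)F)ccn1)nn2[C@@H]1CC[C@H](N)C1`) differs from compound 1 in one place (3-aminocyclopentyl in place of 4-(hydroxymethyl)cyclohexyl on an aromatic nitrogen), with 3-aminocyclopentyl in place of 4-(hydroxymethyl)cyclohexyl on an aromatic nitrogen. Among the compounds with values here, no measured pair shows such a change on its own, so in this assay no step beyond the scatter is expected, in either direction. The estimated step (a 1.1-fold lower number from compound 1 to compound 4 (0.04 log units; within the scatter)) is accordingly small. For compound 4 the estimate is 0.35 h with an expected range from 0.12 h to 1 h for repeat measurements.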

Compound 4, half-life: 1.4 h
For compound 4 the middle estimate is 4.0-fold (0.60 log units) below the measured one, outside the stated range (above it).
By their numbers in this assay, from the lowest: compound 2; then compound 1; then compound 4. At a limit, above all of these: compound 3.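

Within the data shown here, this is the first pair in this assay that differs in one place only, and it shows that the group on the aromatic nitrogen can move this read-out: 3-aminocyclopentyl in place of 4-(hydroxymethyl)cyclohexyl gives a 3.7-fold higher number from compound 1 to compound 4 (0.56 log units; beyond the scatter) while the rest of the molecule stays the same. Nothing shown accounts for this rise.

As far as these compounds go, the swap alters the ring size and the ring's substituent together, so which of the two carries the step stays open. A cyclohexyl ring bearing an amine, or a cyclopentyl ring bearing a hydroxyl, on that nitrogen would separate them.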